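Shortening the hexyl chain to cyclopropyl on a weak core

This account rests on a few compounds, and the source may have more. Where it says the series, first, only, none or still open, it means among the compounds named here.

Measured compounds in a functional assay on CFPAC-1 cells (Homo sapiens) for antiproliferative activity, read by MTT assay, with a stated time of 72 h; a higher number here means a weaker inhibitor, a lower number a stronger inhibitor:
- compound 1 `CCCCCCc1cc2cn(Cc3cn(Cc4ccccc4)nn3)c(=O)nc2o1`: 67000 nM
- compound 2 `CCCCCCC#Cc1c(CCCCCC)oc2nc(=O)n(Cc3cn(Cc4ccccc4)nn3)cc12`: 27300 nM
- compound 3 `CCCCCc1ccc(C#Cc2c(-c3ccc(CCCCC)cc3)oc3nc(=O)n(Cc4cn(-c5ccc(Cl)cc5)nn4)cc23)cc1`: > 100000 nM, which is a limit of this assay and not a number

Among the two numbers given, compound 1 stands as the higher one, that is the weaker inhibitor; its nearest neighbour is compound 2, reached by a 2.5-fold lower number from compound 1 to compound 2 (0.39 log units; beyond the scatter). For compound 3 the assay gives only a limit (the limit of > 100000 nM in this assay, at which 1 of the 3 values shown sits).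

Compound 4 `O=c1nc2oc(C3CC3)cc2cn1Cc1cn(Cc2ccccc2)nn1` differs from compound 1 by cyclopropyl in place of hexyl on an aromatic carbon. Among the measured compounds shown here, no measured pair changes this chain, so no step bears directly on it; the only step known, from compound 1 to compound 2, alters a different position and is modest. The expectation for compound 4 is therefore a number near that of compound 1, with no step beyond the scatter clearly predicted, and the chance of landing at the assay limit is real given how weak compound 1 already is. Compound 4 is estimated at 80000 nM, within 35000 nM to 180000 nM, corresponding to a 1.2-fold higher number from compound 1 to compound 4 (0.08 log units; within the scatter).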

Compound 4, half-maximal inhibitory concentration: 48500 nM
Compound 4: middle estimate off by 1.6-fold (0.22 log units), on the high side, within the range that was stated.
By their numbers in this assay, from the lowest: compounds 2, 4 and 1 (each within the scatter of the next, the first and the last beyond it). At a limit, above all of these: compound 3.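

In this assay, the aromatic carbon next to the ring oxygen now has a step of its own, and the exchange of hexyl for cyclopropyl gives a 1.4-fold lower number from compound 1 to compound 4 (0.14 log units; within the scatter). The open chain of 6 carbon atoms can therefore give way to a three-membered ring of 3 carbon atoms at this place, with no difference that this assay can separate from the usual scatter. Nothing measured here gives a reason for this result.

From the compounds shown here alone, whether an amine or a carboxylic acid at this place would move the number clearly away from that of compound 1 remains open, as does the effect of a chain longer than hexyl. Also open, going by these compounds, is whether adding oct-1-yn-1-yl to the core of compound 4 would give a step like the one seen with the hexyl chain in place.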